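Propylsulfonyl in place of the aryl urea at the anilide nitrogen

This account rests on a few compounds, and the source may have more. Where it says the series, first, only, none or still open, it means among the compounds named here.

Compound 3 `CCOC(=O)c1csc2nc(-c3ccc(NC(=O)Nc4ccc(Br)cn4)cc3)cn12` gives 2440 nM in a functional assay on MV4-11 cells (Homo sapiens) for cytotoxicity, read by MTT assay, with a stated time of 72 h (a higher number here means a weaker inhibitor, a lower number a stronger inhibitor), the lowest of the two numbers in hand. Compound 2 `CCOC(=O)c1csc2nc(-c3ccc(NC(=O)CC)cc3)cn12` gives 9520 nM in this assay, so that the step of a 3.9-fold lower number from compound 2 to compound 3 (0.59 log units; beyond the scatter) is the only measured step among these compounds. Compound 1 `CCOC(=O)c1csc2nc(-c3cccc(NC(=O)c4ccco4)c3)cn12` gives > 20000 nM in this assay; this is the limit of > 20000 nM in this assay, at which 1 of the 3 values shown sits, a limit of the assay and not a number.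

Compound 4 `CCCS(=O)(=O)Nc1ccc(-c2cn3c(C(=O)OCC)csc3n2)cc1` differs from compound 3 by propylsulfonyl in place of (5-bromopyridin-2-yl)carbamoyl on a nitrogen on an aromatic ring. Among the compounds with values here, the single measured step bears on this change only indirectly: a 3.9-fold lower number from compound 2 to compound 3 (0.59 log units; beyond the scatter) shows that the (5-bromopyridin-2-yl)amino group on the carbonyl carbon gave a lower number than ethyl at the same place, and compound 4 removes both the carbonyl and the bromopyridyl group, leaving a propyl chain on a sulfonyl. The number for compound 4 is therefore expected to move back toward that of compound 2 9520 nM, a step in the direction of a weaker inhibitor. For compound 4 the expected value in this assay is 10000 nM, with a range from 3000 nM to 30000 nM. This corresponds to an expected step of a 4.1-fold higher number from compound 3 to compound 4 (0.61 log units; beyond the scatter).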

Compound 4, half-maximal inhibitory concentration: > 20000 nM
Compound 4: a limit, no number; the forecaster's own chance of this, stated with the estimate: 35%; middle value at least 2.0-fold (0.30 log units) away from the limit.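

In this assay, within the data shown here, this nitrogen on an aromatic ring tolerates less than the earlier compounds could show: propylsulfonyl in place of (5-bromopyridin-2-yl)carbamoyl gives an at least 8.1-fold higher number from compound 3 to compound 4 (0.91 log units; beyond the scatter), and propylsulfonyl in place of propanoyl gives an at least 2.1-fold higher number from compound 2 to compound 4 (0.32 log units; beyond the scatter). Until now only carbonyl-linked groups had been compared on this nitrogen, and compound 2 and compound 3 both return numbers, whereas the sulfonyl-linked group of compound 4 falls behind both, even against the small propanoyl group. The reading for compound 4 is a limit of the assay and not a number, so both steps give only a lower bound on the change: the limit of > 20000 nM in this assay, at which 2 of the 4 values shown sit.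

The compounds shown do not separate the sulfonyl link from the loss of the aryl group, which a phenylsulfonyl or (5-bromopyridin-2-yl)sulfonyl group on the same nitrogen would address. As far as these compounds go, how a shorter methylsulfonyl group or a longer butylsulfonyl chain would read there also stays open, as does the behaviour of the free amine at this nitrogen.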